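Chloro in place of fluoro: a distribution estimate

The compounds below may be only part of what the source reports. "The series", "measured", "known", "first", "only" and "open" are said of these compounds alone.

Compound 1 `O=S(=O)(c1cc(Cl)c(O)c2ncccc12)C1CCCC1`: 0.3 L/kg
Compound 2 `O=S(=O)(c1cc(F)c(O)c2ncccc12)N1CCCC1`: 2.2 L/kg

In an ADME assay on the whole organism for pharmacokinetics, with Rattus norvegicus as the target (on this read-out lower numbers stand for narrower distribution and higher numbers for wider distribution into tissues), compound 2 has the higher of the two numbers at 2.2 L/kg, and its gap to compound 1 lies beyond the scatter. Compound 3 `O=S(=O)(c1cc(Cl)c(O)c2ncccc12)N1CCCC1` has not yet been measured. It differs from compound 2 in one place, with chloro in place of fluoro on an aromatic carbon. Compound 3 thus carries the chloro of compound 1 but otherwise matches compound 2. Going by the values given here, no measured pair shows this swap alone, and compounds 1 and 2 differ in more than one place. A lower number is expected, since compound 1 with its chloro gives 0.3 L/kg. The estimated change is modest: a 2.2-fold lower number from compound 2 to compound 3 (0.34 log units; beyond the scatter). For compound 3 the expected value is 1 L/kg, with an estimated range of 0.4 L/kg to 2.5 L/kg.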

Compound 3, volume of distribution at steady state: 0.8 L/kg
Estimate against measurement, compound 3: 1.3-fold (0.10 log units) above; the measured number falls inside the stated range.
By their numbers in this assay, from the lowest: compound 1; then compound 3; then compound 2.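

Chloro in place of fluoro on this aromatic carbon, ortho to a hydroxy group, can now be read as a single change in this assay: it gives a 2.8-fold lower number from compound 2 to compound 3 (0.44 log units; beyond the scatter) with nothing else in the structure altered. Pyrrolidin-1-yl in place of cyclopentyl on the sulfonyl sulfur, with the chloro held fixed, gives a 2.7-fold higher number from compound 1 to compound 3 (0.43 log units; beyond the scatter) as a separate single change, so each of the two differences now has its own modest step. No other measurement bears on why either step occurs.

The compounds shown carry only fluoro and chloro on this carbon, which leaves open how a bromo, a methyl or a nitrile there would compare. Also open, as far as these compounds go, is whether the chloro step keeps its size with cyclopentyl on the sulfonyl sulfur, and how a morpholine would compare with pyrrolidin-1-yl.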